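The source may report more compounds than this note shows. Statements on the series, on what has been measured and on what is new or still open speak of the compounds shown alone.

Working notes on the series.

Three compounds carry a number in an assay on isolated protein for inhibition of kallikrein-7 (Homo sapiens), read by fluorescence, with stated times of 10 min and 30 min; a higher number here means a weaker inhibitor, a lower number a stronger inhibitor. Compound 1 `CCC1=NC(c2cn(S(=O)(=O)c3ccc(C)cc3)c3ccccc23)CN1` gives 24000 nM. Compound 2 `CC1=NC(c2cn(S(=O)(=O)c3ccc(Cl)cc3)c3ccccc23)CN1` gives 5700 nM. Compound 3 `CC1=NC(c2cn(S(=O)(=O)c3cccs3)c3ccc(C)cc23)CN1` gives 11000 nM, the second highest of the three numbers. The gap from compound 3 to compound 2 lies within the usual scatter of the measurement; the gap from compound 3 to compound 1 lies beyond it. Among the compounds with values here, no two measured compounds differ in a single place, so no single-point step can be read from the measured set.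

Compound 4 `CC1=NC(c2cn(S(=O)(=O)c3ccccc3Br)c3ccc(C)cc23)CN1` has not yet been measured. It differs from compound 3 in one place: 2-bromophenyl in place of thiophen-2-yl on a sulfonyl sulfur. The measured compounds 1 and 2 show that a substituted phenyl group on that sulfonyl sulfur, with a different pattern on the shared core, can sit on either side of compound 3 in this assay, so nothing in the data points to a large movement in one direction.

The step from compound 3 to compound 4 is therefore expected to be a 1.4-fold lower number from compound 3 to compound 4 (0.14 log units; within the scatter), not beyond the scatter. Compound 4 is estimated at 8000 nM, with a range from 2500 nM to 25000 nM.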

Compound 4, half-maximal inhibitory concentration: 390 nM
For compound 4 the middle estimate is 21-fold (1.31 log units) above the measured one; measured number outside the range, below it.
By their numbers in this assay, from the lowest: compound 4; then compounds 2 and 3 (each within the scatter of the next); then compound 1.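

In this assay, within the data shown here, putting 2-bromophenyl in place of thiophen-2-yl on a sulfonyl sulfur gives a 28-fold lower number from compound 3 to compound 4 (1.45 log units; beyond the scatter) and is the one step that can be read at a single place. Among these compounds, it shows that this position, on a sulfonyl sulfur whose other neighbour is an aromatic nitrogen, is not indifferent to the group it carries: with the rest of the structure held constant, this one exchange moves the number well beyond the scatter, which the earlier compounds, differing in more than one place, could not show. No measurement in hand bears on what lies behind the size of this step.

The compounds shown leave open whether the step belongs to the bromine or to the six-membered carbon ring, and a plain phenyl group on the sulfonyl sulfur, with the rest of compound 4 kept, would separate the two. Also open, from the compounds shown here alone, is how a chlorine, a methyl group or an amine in place of the bromine would read in this assay on this same core.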